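Working notes: compound 3, the 4-chlorophenyl isomer of compound 2

The source may hold more compounds than are shown below. What is called first, only, known or untested is meant among the compounds shown, and "the series" means these compounds.

Measured so far:
compound 1 `COc1ccccc1NCC(=O)Oc1ccc2c(C)cc(=O)oc2c1`: 26.6%
compound 2 `Cc1cc(=O)oc2cc(OC(=O)CNc3ccccc3Cl)ccc12`: 12.8%

In a functional assay on the whole organism (strain Wistar albino) for inhibition, with Rattus norvegicus as the target, read by paw edema, with stated times of 30 min and 3 h, at a dose of 20 mg/kg by the oral route (on this read-out higher numbers stand for more inhibition at the one dose given (going by the name of the read-out) and lower numbers for less inhibition), compound 1 gives 26.6% and compound 2 gives 12.8%. For the measured compounds named here, compound 2 holds the lower of the two numbers; the only measured step, a number 13.8 percentage points lower from compound 1 to compound 2 (beyond the scatter), lies beyond the scatter but concerns an exchange of one group for another on the aromatic carbon, not a change of where a group sits.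

Compound 3 `Cc1cc(=O)oc2cc(OC(=O)CNc3ccc(Cl)cc3)ccc12` keeps the same atoms as compound 2 and differs by 4-chlorophenyl in place of 2-chlorophenyl on an amine nitrogen. Going by the values given here, no measured step bears on a change of this kind, so nothing in the two numbers at hand points in either direction. The working expectation is therefore no step beyond the scatter. Compound 3 is estimated at 13%, within 4% to 28%, which means an expected step of a number 0.2 percentage points higher from compound 2 to compound 3 (within the scatter).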

Compound 3, a percentage reported as inhibition, in the whole organism at one dose (the size of the read-out at that dose, not a potency): 15.9%
The estimate for compound 3 lay 2.9 percentage points below the measured number; the measured number falls inside the stated range.
By their numbers in this assay, from the lowest: compounds 2 and 3 (each within the scatter of the next); then compound 1.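

In this assay, 4-chlorophenyl in place of 2-chlorophenyl on the amine nitrogen gives a number 3.1 percentage points higher from compound 2 to compound 3 (within the scatter), so for the chlorophenyl pair, where the chlorine sits does not separate the two compounds in this read-out. The exchange of 2-methoxyphenyl for 4-chlorophenyl gives a number 10.7 percentage points lower from compound 1 to compound 3 (beyond the scatter), so both chlorophenyl isomers now stand apart from the 2-methoxyphenyl compound, not only the 2-chlorophenyl one. Nothing at hand accounts for either step.

Open, as far as these compounds go, is whether the methoxy group keeps the higher number wherever it sits: 4-methoxyphenyl on the same amine nitrogen would test that, and an unsubstituted phenyl would show whether methoxy raises the number or chlorine lowers it. With one dose only, the numbers also leave the relative potency of these compounds open.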